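The compounds below may be only part of what the source reports. "The series", "measured", "known", "first", "only" and "open" are said of these compounds alone.

Compound 1, `COc1nc(C)nc(/N=C/c2ccccc2)n1`, is the starting point of this step, but in an ADME assay on Vero cells (Chlorocebus sabaeus) for cytotoxicity, read by MTT assay, with a stated time of 72 h (a higher number here means a weaker inhibitor, a lower number a stronger inhibitor), compound 1 stands at "not determined" (no result reported), so it has no number of its own to compare against. The only other result comes from compound 2, `CCOc1cc(/C=N/c2nc(C)nc(OC)n2)ccc1O`. Compound 2 gives > 50 ug/mL, which is a limit and not a number.

The next compound to be tested is compound 3, `COc1nc(C)nc(/N=C/c2ccc(Cl)cc2)n1`. It differs from compound 1 by one small change: chloro in place of hydrogen on an aromatic carbon, para to a large group. Among the compounds with values here, no measured pair in this assay shows what such a change does, so any expectation here is tentative. The expected step is none beyond the usual scatter, with only a slight lean towards a lower number, which would mean a stronger effect on the cells. Like compound 2, compound 3 may well be expected to return only a limit. If a number is obtained, the estimate for compound 3 is 50 ug/mL, with an expected range from 20 ug/mL to 100 ug/mL.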

Compound 3, half-maximal inhibitory concentration: > 50 ug/mL
Compound 3 was reported as a limit; the forecaster's own chance of this, stated with the estimate: 60%; the middle value lies on the limit itself.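

No step can be read between compound 1 and compound 3: compound 1 stands at "not determined" (no result reported) and offers no number for comparison. Compound 3 gives > 50 ug/mL as a limit and not a number. The compounds shown leave open what chloro in place of hydrogen does in this assay and where their true values lie, with only this limit to go on: the limit of > 50 ug/mL in this assay, at which 2 of the 3 values shown sit.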